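Moving the fluorine: 4-fluorophenyl to 3-fluorophenyl

A few compounds are considered here, and "the series" means these few. Any claim that something is new, unique, unknown or untested is made for them only; others in the source may bear on it.

Measured in a functional assay on HepG2 cells (Homo sapiens) for antiproliferative activity, read by sulforhodamine B assay, with a stated time of 48 h; on this read-out higher numbers stand for weaker inhibition and lower numbers for stronger inhibition:
- compound 1 `COc1ccc(/C=C/C(=O)c2ccccc2-c2ccc(F)cc2)cc1` gives 93 nM
- compound 2 `COc1ccc(/C=C/C(=O)c2ccccc2-c2ccc(F)cc2)cc1OC` gives 95 nM

Within the data shown here, compound 1 does not stand apart from compound 2, as the only measured step shows (a 1.0-fold higher number from compound 1 to compound 2 (0.01 log units; within the scatter)). Compound 3 `COc1ccc(/C=C/C(=O)c2ccccc2-c2cccc(F)c2)cc1` differs from compound 1 by one change (3-fluorophenyl in place of 4-fluorophenyl on an aromatic carbon). The measured step, methoxy in place of hydrogen on an aromatic carbon, does not touch the fluorine, so it bears on this change only weakly. No step beyond the scatter is therefore expected in this assay, and no direction can be firmly expected. The expected change is small (a 1.2-fold higher number from compound 1 to compound 3 (0.07 log units; within the scatter)). For compound 3 the estimated value is 110 nM, with an expected range from 40 nM to 300 nM.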

Compound 3, half-maximal inhibitory concentration: 110 nM
Beside the measured number, compound 3's estimate shows no gap at the digits printed; measured number inside the range.
By their numbers in this assay, from the lowest: compounds 1, 2 and 3 (each within the scatter of the next).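

In this assay 3-fluorophenyl in place of 4-fluorophenyl gives a 1.2-fold higher number from compound 1 to compound 3 (0.07 log units; within the scatter) and so stays within the scatter. Among these compounds, this is the first direct test of the fluorine's placement, which the methoxy step could not provide, and between these two placements the read-out shows no measurable difference. Nothing available here explains this result. Going by these compounds, it remains open whether the fluorine is needed at all, and whether an unsubstituted phenyl would give a similar number. An amine or a carboxylic acid on this ring is also untested among the compounds shown.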